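Compound 1 and its 3,5-dimethoxyphenyl counterpart

The compounds below may be only part of what the source reports. "The series", "measured", "known", "first", "only" and "open" are said of these compounds alone.

In a functional assay on KBVIN cells (Homo sapiens) for antiproliferative activity, read by sulforhodamine B assay, with a stated time of 3 days (a lower number here means a stronger inhibitor of growth, a higher number a weaker inhibitor of growth), compound 1 `COc1ccc(NC(=O)c2cccc(Nc3ncc(F)c(Nc4ccc(F)cc4)n3)c2)cc1` gives 15700 nM, the higher of the two numbers available, which makes it the weaker growth inhibitor of the measured pair. Compound 2 `CN(C)CC(=O)Nc1cccc(Nc2ncc(F)c(Nc3ccc(F)cc3)n2)c1` gives 1810 nM. Among the compounds with values here, the only measured step, an 8.7-fold lower number from compound 1 to compound 2 (0.94 log units; beyond the scatter), puts (((dimethylamino)methyl)carbonyl)amino in place of (4-methoxyphenyl)carbamoyl on an aromatic carbon. Compound 3 `COc1cc(NC(=O)c2cccc(Nc3ncc(F)c(Nc4ccc(F)cc4)n3)c2)cc(OC)c1` differs from compound 1 in a smaller way: 3,5-dimethoxyphenyl in place of 4-methoxyphenyl on an amide-type nitrogen, with 3,5-dimethoxyphenyl in place of 4-methoxyphenyl on an amide-type nitrogen. Within the data shown here, the measured step removes that whole group, so it says little about this exchange, and no measured pair tests the exchange directly. Only a small change in this assay is therefore expected, with no firm direction. The estimated step is a 1.3-fold lower number from compound 1 to compound 3 (0.12 log units; within the scatter), which stays within the usual scatter. The expected value for compound 3 is 12000 nM, with an estimated range of 4000 nM to 30000 nM.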

Compound 3, concentration for 50% growth inhibition: 12700 nM
The estimate for compound 3 lay 1.1-fold (0.02 log units) below the measured number; low and high end bracket the measured number.
By their numbers in this assay, from the lowest: compound 2; then compounds 3 and 1 (each within the scatter of the next).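

In this assay, the exchange of 4-methoxyphenyl for 3,5-dimethoxyphenyl on the amide-type nitrogen gives a 1.2-fold lower number from compound 1 to compound 3 (0.09 log units; within the scatter), so this direct test of the aryl group shows no difference that can be told from scatter. The earlier step, an 8.7-fold lower number from compound 1 to compound 2 (0.94 log units; beyond the scatter), replaced the whole (4-methoxyphenyl)carbamoyl group at once and could not separate the aryl group from the rest of it; this pair shows that, between these two methoxy-substituted phenyl groups, the number holds within the scatter. Nothing measured here bears on the reason for this result.

The compounds shown carry only methoxy groups on this phenyl ring, so it remains open whether a dimethylamino group or a carboxylic acid there would move the number. On these data alone, it also remains open whether the dimethylamino end of compound 2 would lower the number on its own, with the amide linkage of compound 1 kept in place.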